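This account rests on a few compounds, and the source may have more. Where it says the series, first, only, none or still open, it means among the compounds named here.

Measured compounds:
compound 1, `COc1cc2c(cc1OC)C(=O)C(CC1CCN(C(=S)Nc3ccc(C)cc3)CC1)C2`: 100 mg/kg
compound 2, `COc1cc2c(cc1OC)C(=O)C(CC1CCN(C(=S)Nc3cccc([N+](=O)[O-])c3)CC1)C2`: "not determined" (no result reported)

In a functional assay on the whole organism (strain Swiss albino) with Mus musculus as the target, with a stated time of 0.5 h (on this read-out lower numbers stand for an effect already at smaller amounts and higher numbers for an effect only at larger amounts of compound), compound 1 gives 100 mg/kg. Going by the values given here, for compound 2 this assay gave "not determined" (no result reported), so compound 2 stands without a number of its own, and the only value in hand is that of compound 1.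

Compound 3, `CCCCNC(=S)N1CCC(CC2Cc3cc(OC)c(OC)cc3C2=O)CC1`, is the next compound to be tested. It differs from compound 2 in one place: butyl in place of 3-nitrophenyl on an amide-type nitrogen. Among the compounds with values here, since compound 2 carries no number, the step from compound 2 to compound 3 cannot be measured against anything, and no direction can be drawn from it; the expectation for compound 3 in this assay is therefore a step of no particular direction, not beyond the scatter of the only measured value, that of compound 1.

The estimated minimum effective dose of compound 3 in this assay is expected to be about 100 mg/kg, within a range of 30 mg/kg to 300 mg/kg.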

Compound 3, minimum effective dose: 100 mg/kg
For compound 3 middle estimate and measured number coincide at the digits printed; measured number inside the range.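

In this assay, going by these compounds alone, the one step that can be read at this amide-type nitrogen is no change at the digits printed from compound 1 to compound 3 (within the scatter), with butyl in place of 4-methylphenyl. Within the data shown here, a group without a ring thus gives the same reading at this place as one with a six-membered aromatic ring, something the earlier compounds, which both carry an aryl group there, could not show. Compound 2 has no number, so its step to compound 3 cannot be read. Nothing at hand accounts for the two groups reading alike.

On these data alone, whether a shorter chain such as methyl, a longer chain such as octyl, or a cyclohexyl or benzyl group on this nitrogen would shift the minimum effective dose remains open. So does the effect of an amine or a carboxylic acid at the end of the butyl chain.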